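A few compounds are considered here, and "the series" means these few. Any claim that something is new, unique, unknown or untested is made for them only; others in the source may bear on it.

Among the measured compounds shown here, compound 1 `CC(C)[C@H](C(=O)Nc1ccccn1)c1ccc(Cl)cc1` is one of two compounds measured in a functional assay on CHO cells for agonist activity at Free fatty acid receptor 2 (Homo sapiens), read by cAMP accumulation; on this read-out higher numbers stand for larger maximal responses and lower numbers for smaller maximal responses. In this assay compound 1 gives 92%, and compound 2 `CC(C)[C@H](C(=O)Nc1nc2cc(Cl)ccc2o1)c1ccc(Cl)cc1` gives 88%; the two values lie within the scatter of each other, so neither can be set apart. Compound 3 `CC(C)[C@H](C(=O)Nc1ncc(C#N)s1)c1ccc(Cl)cc1` has not yet been measured. It differs from compound 1 in one place: 5-cyano-1,3-thiazol-2-yl in place of pyridin-2-yl on an amide-type nitrogen. For the measured compounds named here, no measured pair shows what this change does. Since both measured compounds reach a full response, the step from compound 1 to compound 3 is expected to be small, a number 7 percentage points lower from compound 1 to compound 3 (within the scatter), perhaps a slight loss. Compound 3 is therefore estimated at 85%, with a range from 60% to 105%.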

Compound 3, largest response reached (reported as efficacy), in percent of the reference or control that the assay uses: 105%
Estimate against measurement, compound 3: 20 percentage points below; low and high end bracket the measured number.
By their numbers in this assay, from the lowest: compounds 2 and 1 (each within the scatter of the next); then compound 3.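

In this assay, among the compounds shown here, 5-cyano-1,3-thiazol-2-yl in place of pyridin-2-yl on the amide-type nitrogen gives the first readable step at this position: a number 13 percentage points higher from compound 1 to compound 3 (beyond the scatter). This place therefore accepts a five-membered aromatic ring bearing a nitrile, and the maximal response does not fall but rises modestly. Nothing available explains this gain.

Whether the nitrile or the five-membered ring accounts for the step stays open, since the two change together. A plain 1,3-thiazol-2-yl, or one carrying a carboxylic acid instead of the nitrile, would help separate them.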